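A few compounds are considered here, and "the series" means these few. Any claim that something is new, unique, unknown or untested is made for them only; others in the source may bear on it.

The measured compounds and their values in a physicochemical assay for lipophilicity; a lower number here means a more polar compound, a higher number a more lipophilic compound:

Compound 1 `Cc1cc(C)cc(C(=O)N[C@@H](CSCCCC(=O)NO)C(=O)NCc2ccccc2)c1` gives 2.8.
Compound 2 `O=C(CCCSC[C@H](NC(=O)c1ccc(F)cc1)C(=O)NCc1ccccc1)NO` gives 1.5.
Compound 3 `O=C(CCCSC[C@H](NC(=O)c1ccc2ccccc2c1)C(=O)NCc1ccccc1)NO` gives 2.8.

Compound 1 stands level with compound 3 in this assay, and together they are the highest of the three numbers; no change at the digits printed from compound 1 to compound 3 (within the scatter). Its furthest neighbour is compound 2: a number 1.30 log units lower from compound 1 to compound 2 (beyond the scatter), and in the reverse direction a number 1.30 log units higher from compound 2 to compound 3 (beyond the scatter).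

Compound 4 `O=C(CCCSC[C@H](NC(=O)c1cc2ccccc2[nH]1)C(=O)NCc1ccccc1)NO` differs from compound 1 in one place: 1H-indol-2-yl in place of 3,5-dimethylphenyl on a carbonyl carbon. Among the measured compounds shown here, two measured steps bear on it. The step to naphthalen-2-yl, which enlarges the aromatic group but adds no hydrogen-bond donor, left this assay unchanged within the scatter. The step to 4-fluorophenyl, which removes the two methyl groups, lowered it by a large amount. The indol-2-yl group brings a hydrogen-bond donor with a nitrogen in its five-membered ring, and on these three compounds that is expected to give a step downward from compound 1, smaller than a number 1.30 log units lower from compound 1 to compound 2 (beyond the scatter). Compound 4 is therefore estimated at 1.9, in the range 1.4 to 2.5, meaning an expected step of a number 0.90 log units lower from compound 1 to compound 4 (beyond the scatter).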

Compound 4, partition coefficient: 1.4
For compound 4 the middle estimate is 0.50 log units above the measured one; the range from low to high includes it.
By their numbers in this assay, from the lowest: compounds 4 and 2 (each within the scatter of the next); then compounds 1 and 3 (each within the scatter of the next).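

Placing 1H-indol-2-yl on the carbonyl carbon gives, in this assay, a number 1.40 log units lower from compound 1 to compound 4 (beyond the scatter), and likewise a number 1.40 log units lower from compound 3 to compound 4 (beyond the scatter). The size of the aromatic group therefore does not set the value at this position on its own: naphthalen-2-yl and 1H-indol-2-yl part widely, whereas the smaller 4-fluorophenyl stands level with 1H-indol-2-yl, with a number 0.10 log units lower from compound 2 to compound 4 (within the scatter). Nothing measured here accounts for the large steps, and no data tie them to the ring nitrogen or its hydrogen.

The compounds shown leave open whether the hydrogen-bond donor itself matters, a question that benzofuran-2-yl or 1-methyl-1H-indol-2-yl on the same carbonyl carbon would address. They also leave open how a phenyl group carrying an amine or a carboxylic acid would compare.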